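The compounds below may be only part of what the source reports. "The series", "measured", "known", "first", "only" and "open" are said of these compounds alone.

Measured compounds:
- compound 1, `CC(C(=O)N1CCN(c2ccccc2F)CC1)N1C(=O)CCC1=O`: 0%
- compound 2, `CCC(C(=O)N1CCN(c2cccc(Cl)c2)CC1)N1C(=O)CCC1=O`: 0%

Both compounds were tested in a functional assay on the whole organism (strain Swiss) with Mus musculus as the target, in the maximal electroshock model, with a stated time of 2 h, at a dose of 100 mg/kg by the intraperitoneal route; a higher number here means a stronger effect of the compound at the dose given, a lower number a weaker effect. In this assay compound 1 gives 0%, and compound 2 gives 0%. Compound 2 therefore stands level with compound 1 at the digits reported, its nearest neighbour, with no change between the two that goes beyond the usual scatter of such measurements. Neither compound shows any measurable effect in this assay at the dose given.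

The piece now follows the step from compound 2 to compound 3, `CC(C(=O)N1CCN(c2cccc(Cl)c2)CC1)N1C(=O)CCC1=O`, which has not yet been measured. Compound 3 differs from compound 2 in one place: hydrogen in place of methyl on a saturated chain carbon, two bonds along the chain from an amide-type nitrogen in a ring and a carbonyl carbon. Among the measured compounds shown here, no step between measured compounds that differ in one place is available, so there is no precedent within this set for a change of this kind. Given that compound 2 gives 0% in this assay, the step expected is no change at the digits printed from compound 2 to compound 3 (within the scatter), that is, none beyond the scatter. Compound 3 is therefore estimated to give 0% in this assay, within a range from 0% to 15%.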

Compound 3, a percentage reported as activity, at one dose (the size of the read-out at that dose, not a potency): 0%
Beside the measured number, compound 3's estimate shows no gap at the digits printed; measured number inside the range.
By their numbers in this assay, from the lowest: compounds 1, 2 and 3 (each within the scatter of the next).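

In this assay, hydrogen in place of methyl on a saturated chain carbon, two bonds along the chain from an amide-type nitrogen in a ring and a carbonyl carbon, gives no change at the digits printed from compound 2 to compound 3 (within the scatter), so this change, which also reads as ethyl to methyl when cut one bond further out, leaves the read-out unmoved. With compound 3 in hand, the aryl group on the amine nitrogen in a ring can also be read as a single change: 3-chlorophenyl in place of 2-fluorophenyl gives no change at the digits printed from compound 1 to compound 3 (within the scatter). No measured finding on any other property bears on these results, and the reason neither change registers remains unknown.

All of these steps start and end at a read-out with no effect, so they cannot show whether either position would matter in a compound that has some effect at this dose. As far as these compounds go, it remains open whether a longer chain on the saturated carbon, or a methoxyphenyl or pyridyl group in place of the 3-chlorophenyl, would give any effect in this assay.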